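The source may hold more compounds than are shown below. What is called first, only, known or untested is meant among the compounds shown, and "the series" means these compounds.

Measured compounds in a functional assay on HeLa cells (Homo sapiens) for cytotoxicity, read by MTT assay, with a stated time of 48 h; on this read-out lower numbers stand for stronger inhibition and higher numbers for weaker inhibition:
compound 1 `COc1ccc(-c2cc(C(=O)Nc3nc4ccc(Cl)cc4s3)nc3cc(-c4ccccc4)nn23)cc1` gives 5880 nM
compound 2 `COc1ccc(-c2cc(C(=O)Nc3nc4ccccc4s3)nc3cc(-c4ccccc4)nn23)cc1` gives 4670 nM
compound 3 `COc1ccc(-c2cc(C(=O)Nc3nc4ccccc4s3)nc3cc(-c4ccccc4)nn23)cc1OC` gives 8910 nM

Compound 2 has the lowest number of the three, but its neighbours are close: the step of a 1.3-fold lower number from compound 1 to compound 2 (0.10 log units; within the scatter) and the step of a 1.9-fold higher number from compound 2 to compound 3 (0.28 log units; within the scatter) are both within the usual scatter, so none of the three can be called more or less potent than another on these data.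

Compound 4 `COc1ccc(-c2cc(C(=O)Nc3nc4cc(C)c(C)cc4s3)nc3cc(-c4ccccc4)nn23)cc1` has not yet been measured. It differs from compound 2 in one place: 5,6-dimethyl-1,3-benzothiazol-2-yl in place of 1,3-benzothiazol-2-yl on an amide-type nitrogen. The two steps seen so far each changed a single ring substituent, one on the same benzothiazolyl group as in the present change, one on the shared core, and neither moved the number beyond the scatter. On that basis the step from compound 2 to compound 4 is expected to be small as well, with no clear direction, as a 1.1-fold higher number from compound 2 to compound 4 (0.03 log units; within the scatter). Compound 4 is therefore estimated at 5000 nM, with a likely range from 2000 nM to 12000 nM in this assay.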

Compound 4, half-maximal inhibitory concentration: 14100 nM
Estimate against measurement, compound 4: 2.8-fold (0.45 log units) below; the whole stated range lies below it.
By their numbers in this assay, from the lowest: compounds 2, 1, 3 and 4 (each within the scatter of the next, the first and the last beyond it).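

In this assay, going by these compounds alone, the benzothiazolyl group on the amide-type nitrogen is the first place in this set where a single change moves the number beyond the scatter: a 3.0-fold higher number from compound 2 to compound 4 (0.48 log units; beyond the scatter). The result is the same against the chloro-bearing group, a 2.4-fold higher number from compound 1 to compound 4 (0.38 log units; beyond the scatter), so 5,6-dimethyl-1,3-benzothiazol-2-yl gives weaker inhibition than both 1,3-benzothiazol-2-yl and 6-chloro-1,3-benzothiazol-2-yl, even though those two lie within the scatter of each other. This position is therefore not indifferent to what it carries, though no measurement here explains the shift.

From the compounds shown here alone, it remains open whether a single methyl group would give the same step or both are needed. Going by these compounds, how an amine or a carboxylic acid on this benzothiazolyl group would read also remains open.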